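A Nitro Group Replaces Hydrogen: Expected Effect on Writhing

The source may report more compounds than this note shows. Statements on the series, on what has been measured and on what is new or still open speak of the compounds shown alone.

Compound 1 `O=C1N/C(=N/c2ccccc2)S/C1=C\c1ccccn1` gives 29.2% in a functional assay on the whole organism (strain Swiss albino) for inhibition, with Mus musculus as the target, in the writhing test, with stated times of 30 min and 15 min, at a dose of 50 mg/kg by the oral route (on this read-out lower numbers stand for less inhibition and higher numbers for more inhibition at the one dose given (going by the name of the read-out)), the lowest of the three measured values. Compound 2 `O=C1N/C(=N/c2ccc(Cl)cc2)S/C1=C\c1ccccn1` gives 41.7% in this assay, and compound 3 `Cc1ccc(/N=C2/NC(=O)/C(=C/c3ccccn3)S2)cc1` gives 43.2% in this assay. Compound 4 `O=C1N/C(=N/c2cccc([N+](=O)[O-])c2)S/C1=C\c1ccccn1` has not yet been measured; it differs from compound 1 in one place: nitro in place of hydrogen on an aromatic carbon. For the measured compounds named here, two measured steps bear on this change, each adding a group on the same aromatic ring of compound 1: a number 12.5 percentage points higher from compound 1 to compound 2 (beyond the scatter) and a number 14 percentage points higher from compound 1 to compound 3 (beyond the scatter). Because a number 12.5 percentage points higher from compound 1 to compound 2 (beyond the scatter) and a number 14 percentage points higher from compound 1 to compound 3 (beyond the scatter) were both modest rises beyond the scatter, a rise of similar size is expected for the nitro group, with added uncertainty since nitro is a different group from chloro or methyl. Compound 4 is therefore estimated at 40%, within 28% to 52%, which means an expected step of a number 10.8 percentage points higher from compound 1 to compound 4 (beyond the scatter).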

Compound 4, a percentage reported as inhibition, in the whole organism at one dose (the size of the read-out at that dose, not a potency): 62.3%
The estimate for compound 4 lay 22.3 percentage points below the measured number; measured number above the stated range.
By their numbers in this assay, from the lowest: compound 1; then compounds 2 and 3 (each within the scatter of the next); then compound 4.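

In this assay, a number 33.1 percentage points higher from compound 1 to compound 4 (beyond the scatter) is a large step, while a number 12.5 percentage points higher from compound 1 to compound 2 (beyond the scatter) and a number 14 percentage points higher from compound 1 to compound 3 (beyond the scatter) are modest. A single group on this aromatic ring can therefore shift the number far more than chloro or methyl did. Nothing here explains why nitro gives so large a step.

Compound 4 carries its group meta to a large group, unlike compounds 2 and 3, so the group and its place cannot be separated. Chloro, methyl, an amine or a carboxylic acid at that same place would help to tell them apart.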